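This account rests on a few compounds, and the source may have more. Where it says the series, first, only, none or still open, it means among the compounds named here.

Going by the values given here, compound 1, with the structure `COc1cc(/C=C/C(=O)C2=C(/C=C/c3ccc(O)c(OC)c3)NC(=O)NC2c2ccccc2)ccc1O`, is one of three compounds measured in a functional assay, with a stated time of 20 min, tested at 50 uM; a higher number here means a stronger effect of the compound at the concentration tested, a lower number a weaker effect. In this assay compound 1 gives 50.2%, the lowest of the three numbers. Compound 2, `COc1cc(/C=C/C(=O)C2=C(/C=C/c3ccc(O)c(OC)c3)NC(=O)NC2c2ccc(C)cc2)ccc1O`, gives 52.2%, and compound 3, `COc1cc(/C=C/C(=O)C2=C(/C=C/c3ccc(O)c(OC)c3)NC(=O)NC2c2ccc(O)cc2)ccc1O`, gives 86.2%. Going from compound 1 to compound 2, methyl in place of hydrogen on an aromatic carbon, gives a number 2 percentage points higher from compound 1 to compound 2 (within the scatter). Going from compound 1 to compound 3, hydroxy in place of hydrogen on an aromatic carbon, gives a number 36 percentage points higher from compound 1 to compound 3 (beyond the scatter), and from compound 2 to compound 3 the step is a number 34 percentage points higher from compound 2 to compound 3 (beyond the scatter).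

Compound 4, `COc1cc(/C=C/C(=O)C2=C(/C=C/c3ccc(O)c(OC)c3)NC(=O)NC2c2ccccc2Cl)ccc1O`, differs from compound 1 in one place: chloro in place of hydrogen on an aromatic carbon. The entering chloro, like the methyl of compound 2, carries no hydrogen-bond donor and no hydrogen-bond acceptor, whereas the hydroxy of compound 3 brings a donor. Among the compounds with values here, the step most like this one is therefore the one from compound 1 to compound 2, which stayed within the scatter, so no change beyond the scatter is expected, and the estimated step is a number 1.8 percentage points higher from compound 1 to compound 4 (within the scatter). Compound 4 is expected to give about 52%, between 38% and 66%.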

Compound 4, a percentage reported as activity, at one concentration (the size of the read-out at that concentration, not a potency): 56%
For compound 4 the middle estimate is 4 percentage points below the measured one, within the range that was stated.
By their numbers in this assay, from the lowest: compounds 1, 2 and 4 (each within the scatter of the next); then compound 3.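

In this assay, chloro on the phenyl ring, ortho to a large group, gives a number 5.8 percentage points higher from compound 1 to compound 4 (within the scatter), so this second group without a hydrogen-bond donor, placed differently from the methyl of the 4-methylphenyl, also leaves the read-out within the scatter. The change to 2-chlorophenyl gives a number 3.8 percentage points higher from compound 2 to compound 4 (within the scatter), but a number 30.2 percentage points lower from compound 3 to compound 4 (beyond the scatter), which keeps the 4-hydroxyphenyl of compound 3 apart from the other three compounds, although this last step changes both the group and its place on the ring. Nothing available here explains why the hydroxy compound stands apart.

As far as these compounds go, it remains open whether hydroxy would give a similar step at the place held by chloro in compound 4. From the compounds shown here alone, it is also open whether an amine or a carboxylic acid on this ring would match compound 3 or the other three compounds.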